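Notes on the carbamate nitrogen substituent and binding

The source may hold more compounds than are shown below. What is called first, only, known or untested is meant among the compounds shown, and "the series" means these compounds.

Compound 1 `CCCCNC(=O)OC[C@H]1OC(n2cnc3c(NC4CCOC4)ncnc32)[C@H](O)[C@@H]1O` gives 1410 nM in an assay on DDT1 cells (Cricetulus griseus) for binding affinity to adenosine receptor A1 (Homo sapiens), read by radioligand binding; a higher number here means a weaker inhibitor, a lower number a stronger inhibitor. Going by the values given here, compound 2 `C=CCNC(=O)OC[C@H]1OC(n2cnc3c(NC4CCOC4)ncnc32)[C@H](O)[C@@H]1O` gives 524 nM in this assay and stands as the lower of the two numbers so far, with compound 1 as its only neighbour. Among the compounds with values here, the single measured step, a 2.7-fold lower number from compound 1 to compound 2 (0.43 log units; beyond the scatter), changes only the chain on the carbamate nitrogen.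

Compound 3 `CN(C)C(=O)OC[C@H]1OC(n2cnc3c(NC4CCOC4)ncnc32)[C@H](O)[C@@H]1O` carries dimethylamino in place of allylamino on a carbonyl carbon. Here the hydrogen on the carbamate nitrogen is lost and the unsaturated chain gives way to two methyl groups; no measured pair in the series varies that hydrogen. The step from compound 1 to compound 2 bears on this only loosely, since it altered the chain rather than the substitution pattern on the nitrogen. A step of no more than modest size in this assay is therefore expected, direction uncertain, leaning towards a somewhat higher number. The expected step is a 1.5-fold higher number from compound 2 to compound 3 (0.18 log units; within the scatter). Compound 3 is estimated at 800 nM, between 300 nM and 2500 nM.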

Compound 3, inhibition constant: 238 nM
Compound 3: the middle estimate sits 3.4-fold (0.53 log units) above what was measured; the whole stated range lies above it.
By their numbers in this assay, from the lowest: compound 3; then compound 2; then compound 1.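

Replacing allylamino with dimethylamino on the carbonyl carbon gives a 2.2-fold lower number from compound 2 to compound 3 (0.34 log units; beyond the scatter) in this assay, and replacing butylamino with dimethylamino gives a 5.9-fold lower number from compound 1 to compound 3 (0.77 log units; beyond the scatter). Among these three compounds, a hydrogen-bond donor on the carbamate nitrogen is therefore not needed for the lowest number, which belongs to compound 3, the one compound without that donor. No measurement shown here bears on the reason for either step.

The step from compound 2 changes the hydrogen and the chain together, leaving open whether the lower number tracks the lost amide hydrogen or the two methyl groups. Methylamino on the same carbonyl carbon would help separate the two, while diethylamino or pyrrolidine would show how far the trend extends beyond dimethylamino.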